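Swapping a carbamate chain for a methoxymethyl group

The source may hold more compounds than are shown below. What is called first, only, known or untested is meant among the compounds shown, and "the series" means these compounds.

Measured compounds:
- compound 1 `CC1=C(N2CC2)C(=O)C(CC(C)OC(N)=O)=C(N2CC2)C1=O`: 6.14
- compound 2 `O=C1C(CCO)=C(N2CC2)C(=O)C(CCO)=C1N1CC1`: 6.54
- compound 3 `CCOC(COC(N)=O)C1=C(N2CC2)C(=O)C(C)=C(N2CC2)C1=O`: 6.18

These three compounds share a core carrying two aziridine rings and differ in the side chains attached to it. They were tested in a functional assay on L1210 cells (Mus musculus), with a stated time of 12 days; on this read-out lower numbers stand for lower potency and higher numbers for higher potency (the scale is a negative logarithm). In this assay compound 1 gives 6.14, the lowest of the three numbers. Compound 3 gives 6.18, a value so close to that of compound 1 that the two lie within the usual scatter of repeated measurements. Compound 2 gives 6.54, which stands beyond the scatter above compound 1.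

Compound 4 `COCCC1=C(N2CC2)C(=O)C(C)=C(N2CC2)C1=O` has not yet been measured. Compared with compound 1, the change is a group of 3 heavy atoms (2 carbon, 1 oxygen; no ring) in place of a group of 6 heavy atoms (3 carbon, 1 nitrogen, 2 oxygen; no ring), on a saturated chain carbon bound to a double-bonded ring carbon. For the measured compounds named here, no pair of measured compounds differs in exactly this way, so the step has to be judged from the spread of the three numbers, which is narrow. A small step is expected, with a slight lean upward, since the simpler-chained compound 2 gives the highest of the three values. The step from compound 1 to compound 4 is estimated at a number 0.16 log units higher from compound 1 to compound 4 (within the scatter). Compound 4 is therefore expected to give about 6.3, within a range from 5.8 to 6.8.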

Compound 4, logarithm of the reciprocal of the active concentration, log(1/C): 5.57
Compound 4: middle estimate off by 0.73 log units, on the high side, outside the stated range (below it).
By their numbers in this assay, from the lowest: compound 4; then compounds 1 and 3 (each within the scatter of the next); then compound 2.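

In this assay, replacing the carbamate chain of compound 1 with methoxymethyl, on a saturated chain carbon bound to a double-bonded ring carbon, gives a number 0.57 log units lower from compound 1 to compound 4 (beyond the scatter) and so moves the read-out clearly. The earlier compounds shown here lay close together and no two of them differed in one place, so they could not show that a change at this position alone can lower the number; this step shows that the group here is not interchangeable with a smaller one that has fewer heteroatoms and no hydrogen-bond donor. Nothing available here explains the drop or tells whether the loss of the donor, the loss of atoms or some other difference matters most.

Which part of the departing chain carries the difference therefore remains open, as does the question of whether any other group at this place could match or pass compound 1. For the compounds shown here, a primary amine, a carboxylic acid or a longer ether chain on the same carbon would each test this position with only one change from compound 4.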